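This account rests on a few compounds, and the source may have more. Where it says the series, first, only, none or still open, it means among the compounds named here.

Measured compounds:
- Compound 1 `CCCCOC(=O)c1cccc(-c2cc(C(=O)Nc3ccncc3)ccc2CN)c1`: 5.5 nM
- Compound 2 `NCc1ccc(C(=O)Nc2ccncc2F)cc1-c1cccc(C(=O)OCC2CC2)c1`: 2.7 nM
- Compound 3 `NCc1ccc(C(=O)Nc2ccncc2)cc1-c1cccc(C(=O)OCC2CCCC2)c1`: 5 nM

In an assay on isolated protein for inhibition of Rho-associated protein kinase 2 (Homo sapiens), read by radiometric assay (on this read-out higher numbers stand for weaker inhibition and lower numbers for stronger inhibition), compound 2 gives the lowest of the three numbers; its gap to compound 3 lies within the scatter, while its gap to compound 1 lies just beyond it. The unmeasured compound 4 `NCc1ccc(C(=O)Nc2ccncc2F)cc1-c1cccc(C(=O)OC2CCCOC2)c1` differs from compound 2 by oxan-3-yl in place of cyclopropylmethyl on an oxygen next to a carbonyl group. Going by the values given here, the only measured step at this place is a 1.1-fold lower number from compound 1 to compound 3 (0.04 log units; within the scatter), which left the number essentially unchanged. On that basis the step from compound 2 to compound 4 is expected to stay within the scatter, with no clear direction, as a 1.3-fold higher number from compound 2 to compound 4 (0.11 log units; within the scatter). Compound 4 is therefore estimated at 3.5 nM in this assay, within a range of 1.5 nM to 9 nM.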

Compound 4, half-maximal inhibitory concentration: 8.7 nM
Compound 4: middle estimate off by 2.5-fold (0.40 log units), on the low side; low and high end bracket the measured number.
By their numbers in this assay, from the lowest: compounds 2, 3, 1 and 4 (each within the scatter of the next, the first and the last beyond it).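

On an oxygen next to a carbonyl group, oxan-3-yl in place of cyclopropylmethyl gives a 3.2-fold higher number from compound 2 to compound 4 (0.51 log units; beyond the scatter) in this assay, so this place does respond to the group it carries, if modestly. The earlier step, a 1.1-fold lower number from compound 1 to compound 3 (0.04 log units; within the scatter), had exchanged groups of carbon only and suggested no such response. The entering oxan-3-yl differs from cyclopropylmethyl in both size and its ring oxygen, and this single step cannot separate the two.

Nothing available explains the step. Going by these compounds, how cyclohexyl or a ring amine would read at this place remains open.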